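A few compounds are considered here, and "the series" means these few. Any claim that something is new, unique, unknown or untested is made for them only; others in the source may bear on it.

Measured so far in an ADME assay on MDCK cells (Canis lupus familiaris) for cytotoxicity, read by MTT assay, with a stated time of 72 h; a lower number here means that less compound is tolerated, a higher number that more compound is tolerated:
compound 1 `CC(=O)Nc1ccc(S(=O)(=O)n2cc([N+](=O)[O-])nc2C)cc1` — 1030000 nM
compound 2 `Cc1nc([N+](=O)[O-])cn1CC(=O)Nc1c(Cl)cccc1Cl` — 396000 nM
compound 3 `Cc1nc([N+](=O)[O-])cn1CC(=O)Nc1cccc(C(F)(F)F)c1` — 435000 nM

Among these three, compound 1 gives the highest number in this assay, meaning the cells tolerate more of it than of either other compound; its gap to compound 3 and to compound 2 lies beyond the usual scatter of repeated measurements. Compound 2 and compound 3 sit close enough to each other that no order between them can be read.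

Compound 4 `Cc1nc([N+](=O)[O-])cn1S(=O)(=O)c1ccc(F)cc1` has not been measured yet. It keeps the core of compound 1 and differs in one place: fluoro in place of acetamido on an aromatic carbon. The acetamido group, which carries the amide hydrogen and a carbonyl, is gone, and a single fluorine stands on that aromatic carbon instead.

Among the measured compounds shown here, no measured pair shows what such a swap does in this assay, so the size of the step can only be guessed. Since all three measured compounds are tolerated at very high concentrations, the change is expected to shift the number by little, if at all, and at most to a modestly lower value; the step of a 1.6-fold lower number from compound 1 to compound 4 (0.20 log units; within the scatter) is the expected outcome. Compound 4 is therefore estimated at 650000 nM, with a range from 250000 nM to 1500000 nM.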

Compound 4, half-maximal cytotoxic concentration: 813000 nM
The estimate for compound 4 lay 1.3-fold (0.10 log units) below the measured number; low and high end bracket the measured number.
By their numbers in this assay, from the lowest: compounds 2, 3, 4 and 1 (each within the scatter of the next, the first and the last beyond it).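

In this assay the swap of fluoro for acetamido on this aromatic carbon, para to a large group, gives a 1.3-fold lower number from compound 1 to compound 4 (0.10 log units; within the scatter), so the two compounds cannot be told apart in this measurement. Among the compounds shown here, this is the first direct view of this position, since the earlier compounds included no pair differing in one place. It shows that, on the core of compound 1, the whole acetamido group, with its amide hydrogen and its carbonyl, can give way to a single fluorine without a readable shift in how much compound the cells tolerate. Nothing available explains why the swap leaves the number within the scatter.

A single swap cannot show whether this position is insensitive to change in general, and an amine, a carboxylic acid or a longer chain at the same aromatic carbon might yet move the number beyond the scatter. On these data alone, it also remains open whether fluoro in place of acetamido would give a similar result on a different core, as this one pair speaks only for the core of compound 1.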